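The source may report more compounds than this note shows. Statements on the series, on what has been measured and on what is new or still open speak of the compounds shown alone.

Compound 1 `CC(=O)N[C@@H]1CCC[C@H](C(=O)Nc2cc(-c3cnc(C)n3C(C)C)ccn2)C1` gives 3.6 mL.min-1.g-1 in an ADME assay on microsomes from liver (Homo sapiens) for metabolic stability; a higher number here means faster removal of the compound, a lower number slower removal.
Compound 2 `CC(=O)N[C@@H]1CCC[C@H](C(=O)Nc2cc(-c3cnn4c3CCC4)c(Cl)cn2)C1` reaches only the limit of this assay, < 3 mL.min-1.g-1.
Compound 3 `CC(=O)N[C@@H]1CCC[C@H](C(=O)Nc2cc(-c3cnn4c3OCCC4)c(Cl)cn2)C1` likewise reaches only the limit, < 3 mL.min-1.g-1.

Compound 2 therefore stands at a limit rather than at a number, and one of the other two values shown is also a limit, so its place among the three cannot be read off exactly; only compound 1 gives a readable number. The new compound, compound 4 `CC(=O)N[C@@H]1CCC[C@H](C(=O)Nc2cc(-c3cnn4c3CC(C)(C)C4)c(Cl)cn2)C1`, differs from compound 2 in one place: a group of 10 heavy atoms (8 carbon, 2 nitrogen; one five-membered non-aromatic ring with 1 hetero atom, one five-membered aromatic ring with 2 hetero atoms) in place of a group of 8 heavy atoms (6 carbon, 2 nitrogen; one five-membered non-aromatic ring with 1 hetero atom, one five-membered aromatic ring with 2 hetero atoms), on an aromatic carbon. Among the measured compounds shown here, the only measured step at this position, a step that the two limits leave unreadable from compound 2 to compound 3, runs between two limits and so says nothing about size or direction. What can be said is the limit of < 3 mL.min-1.g-1 in this assay, at which 2 of the 3 values shown sit, which places compound 2 at the low end of what this assay reports. A shift beyond the scatter from compound 2 to compound 4 is therefore not expected, and the step is estimated at an at least 1.1-fold higher number from compound 2 to compound 4 (0.06 log units; that floor lies within the scatter). Compound 4 is expected to give about 3.5 mL.min-1.g-1, between 2 mL.min-1.g-1 and 8 mL.min-1.g-1.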

Compound 4, intrinsic clearance in microsomes: 50 mL.min-1.g-1
Compound 4: middle estimate off by 14-fold (1.15 log units), on the low side, and the stated range ends below it.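

In this assay, the group on the aromatic carbon opposite the ring nitrogen turns out to matter: a group of 10 heavy atoms in place of one of 8 heavy atoms, with the same ring types and the same hydrogen-bond donor and acceptor counts, gives an at least 16-fold higher number from compound 2 to compound 4 (1.22 log units; beyond the scatter). Set against the oxygen-containing group of 9 heavy atoms, the same group gives an at least 16-fold higher number from compound 3 to compound 4 (1.22 log units; beyond the scatter), so both readable steps run the same way. The step from compound 2 to compound 3 cannot be read, and both new steps are floors set by a limit: the limit of < 3 mL.min-1.g-1 in this assay, at which 2 of the 4 values shown sit.

From the compounds shown here alone, it stays open whether a single methyl group, a fluorine or a hydroxyl group on the five-membered non-aromatic ring would give a number like that of compound 4 or stay near the limit. Going by these compounds, it also stays open how far this change depends on the chloro group.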